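Replacing the basic side chain of a sulfonamide with tert-butyl

A few compounds are considered here, and "the series" means these few. Any claim that something is new, unique, unknown or untested is made for them only; others in the source may bear on it.

Of the compounds shown here, three sharing one core have been measured in an assay on CHO cells for displacement of a labelled ligand from prostaglandin D2 receptor 2 (Homo sapiens), read by scintillation counting; a higher number here means a weaker inhibitor, a lower number a stronger inhibitor. Compound 1 `Cc1ccc(S(=O)(=O)CCO)cc1C#Cc1cc(Cl)ccc1OCC(=O)O` gives 19 nM. Compound 2 `Cc1ccc(S(=O)(=O)N(C)CCCN(C)C)cc1C#Cc1cc(Cl)ccc1OCC(=O)O` gives 287 nM, and compound 3 `Cc1ccc(S(=O)(=O)N(C)CCN(C)C)cc1C#Cc1cc(Cl)ccc1OCC(=O)O` gives 369 nM. Compound 3 thus stands at the highest of the three numbers, though its gap to compound 2 is within the scatter, as the step of a 1.3-fold higher number from compound 2 to compound 3 (0.11 log units; within the scatter) shows; its gap to compound 1 is large, a 19-fold higher number from compound 1 to compound 3 (1.29 log units; beyond the scatter).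

Compound 4 `Cc1ccc(S(=O)(=O)NC(C)(C)C)cc1C#Cc1cc(Cl)ccc1OCC(=O)O` differs from compound 3 in one place: (tert-butyl)amino in place of (2-(dimethylamino)ethyl)(methyl)amino on a sulfonyl sulfur

For the measured compounds named here, the steps that bear on this are a 15-fold higher number from compound 1 to compound 2 (1.18 log units; beyond the scatter) and a 19-fold higher number from compound 1 to compound 3 (1.29 log units; beyond the scatter), both large and both going from a sulfone to a sulfonamide carrying a dimethylamino chain, while a 1.3-fold higher number from compound 2 to compound 3 (0.11 log units; within the scatter) shows that the length of that chain made no difference beyond the scatter. Going by the values given here, no measured step removes the dimethylamino group from a sulfonamide, so whether the large losses belong to the sulfonamide itself or to the basic chain is not known. Compound 4 is therefore expected to sit between compound 1 and compound 3, with an estimated 100 nM and a range of 25 nM to 400 nM. This estimate amounts to an expected step of a 3.7-fold lower number from compound 3 to compound 4 (0.57 log units; beyond the scatter).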

Compound 4, inhibition constant: 5 nM
The estimate for compound 4 lay 20-fold (1.30 log units) above the measured number, outside the stated range (below it).
By their numbers in this assay, from the lowest: compound 4; then compound 1; then compounds 2 and 3 (each within the scatter of the next).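

The step of a 74-fold lower number from compound 3 to compound 4 (1.87 log units; beyond the scatter) shows that a sulfonamide at this position, on a sulfonyl sulfur whose other neighbour is an aromatic carbon, need not carry a large loss, and a 57-fold lower number from compound 2 to compound 4 (1.76 log units; beyond the scatter) points the same way. The losses seen earlier therefore go with the two dimethylamino-bearing groups and not with every sulfonamide, and a 3.8-fold lower number from compound 1 to compound 4 (0.58 log units; beyond the scatter) in this assay even places the (tert-butyl)amino compound on the stronger side of the 2-hydroxyethyl sulfone. Nothing available explains these steps.

The change replaces the chain and adds a hydrogen on the sulfonamide nitrogen in one move, so the compounds shown do not tell which of these matters. From the compounds shown here alone, a (2-(dimethylamino)ethyl)amino group or a (tert-butyl)(methyl)amino group would separate the two, and whether smaller groups such as cyclopropylamino hold the gain also remains open.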